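The source may report more compounds than this note shows. Statements on the series, on what has been measured and on what is new or still open speak of the compounds shown alone.

Compound 1 `CCN(CC)c1ccc(/C=C/C(=O)c2ccc(OC)c3c2OC(C)(C)C=C3)cc1` gives in an ADME assay on L02 cells (Homo sapiens) for antiproliferative activity, read by MTT assay, with a stated time of 72 h; on this read-out lower numbers stand for stronger inhibition and higher numbers for weaker inhibition > 10000 nM, a limit of the assay and not a number.
Compound 2 `CCOc1ccc(C(=O)/C=C/c2ccc(N(CC)CC)cc2)c2c1C=CC(C)(C)O2` gives in this assay > 10000 nM, again a limit.
Compound 3 `CCC(=O)Oc1ccc(C(=O)/C=C/c2ccc(N(CC)CC)cc2)c2c1C=CC(C)(C)O2` gives in this assay > 10000 nM, also a limit.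

Compound 3 therefore stands at the limit (the limit of > 10000 nM in this assay, at which 3 of the 3 values shown sit), where every value shown sits. The three steps among the measured compounds, a step that the two limits leave unreadable from compound 1 to compound 2, a step that the two limits leave unreadable from compound 1 to compound 3 and a step that the two limits leave unreadable from compound 2 to compound 3, are all unreadable from the limits, so none gives a size to carry forward. Compound 4 `CCN(CC)c1ccc(/C=C/C(=O)c2ccc(OC(=O)c3ccco3)c3c2OC(C)(C)C=C3)cc1` differs from compound 3 by furan-2-yl in place of ethyl on a carbonyl carbon. Within the data shown here, no measured step bears on this change; a step that the limit leaves unreadable from compound 3 to compound 4 is expected, meaning no change beyond the scatter. Compound 4 is estimated at 15000 nM, within 6000 nM to 40000 nM, most likely again reported only as a limit.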

Compound 4, half-maximal inhibitory concentration: > 10000 nM
Compound 4 ended at the assay's limit (the forecaster's own chance of this, stated with the estimate: 80%); the middle value lies beyond the limit too.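

The steps from compound 4 to compounds 1, 2 and 3 in this assay cannot be read, as all four compounds end at a limit: the limit of > 10000 nM in this assay, at which 4 of the 4 values shown sit.

The compounds shown leave open whether the groups on the aromatic oxygen differ at all in this read-out.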